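This account rests on a few compounds, and the source may have more. Where it says the series, first, only, none or still open, it means among the compounds named here.

Of the compounds shown here, three sharing one core have been measured in a functional assay on HCC 2998 cells (Homo sapiens) for cytotoxicity, read by sulforhodamine B assay, with a stated time of 48 h, tested at 1 uM; a lower number here means a stronger effect, a higher number a weaker effect of the compound at the concentration tested. Compound 1, `COc1cc(C)cc(-c2c(-c3ccnc(-c4ccc(C(C)=O)cc4)c3)cnn2CC#N)c1`, gives 2%. Compound 2, `Cc1cc(O)cc(-c2nn(CC#N)cc2-c2ccnc(-c3ccc(Oc4ccccc4)cc3)c2)c1`, gives -94%. Compound 3, `COc1cc(C)cc(-c2nn(CC#N)cc2-c2ccnc(-c3ccc(N(C)C)cc3)c2)c1`, gives -51%. Among these three numbers compound 3 stands second highest: compound 2 sits lower and compound 1 higher, both gaps beyond the usual scatter, so compound 3 lies between a compound that strongly reduces the cells and one that barely affects them.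

Compound 4, `Cc1cc(O)cc(-c2nn(CC#N)cc2-c2ccnc(-c3ccc(N(C)C)cc3)c2)c1`, has not yet been measured. It differs from compound 3 in a single place: hydrogen in place of methyl on an oxygen on an aromatic ring. Cut one bond further out, the change reads methoxy to hydroxy, or 3-methoxy-5-methylphenyl to 3-hydroxy-5-methylphenyl. Within the data shown here, no pair of measured compounds differs in exactly this way, so the size of the step is not known from a direct comparison. Among the measured compounds shown here, the only hint is that compound 2, which carries the hydroxy group but also a different group on the other ring, gives a lower number than compound 3.

The step from compound 3 to compound 4 is expected to be a number 19 percentage points lower from compound 3 to compound 4 (beyond the scatter), a lowering of moderate size, beyond the scatter but uncertain in magnitude. Compound 4 is therefore estimated to give -70%, within a range from -95% to -35%.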

Compound 4, a percentage reported as activity, at one concentration (the size of the read-out at that concentration, not a potency): 13%
Compound 4: middle estimate off by 83 percentage points, on the low side; measured number above the stated range.
By their numbers in this assay, from the lowest: compound 2; then compound 3; then compound 1; then compound 4.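

In this assay, the change from methoxy to hydroxy on the 3-methoxy-5-methylphenyl group, with dimethylamino kept on the other ring, gives a number 64 percentage points higher from compound 3 to compound 4 (beyond the scatter), so the strong effect of compound 3 at this concentration is lost. This shows that removing a single methyl from this oxygen can change the result greatly, and the hydroxy group alone does not secure a low number: with hydroxy held constant, dimethylamino in place of phenoxy on an aromatic carbon gives a number 107 percentage points higher from compound 2 to compound 4 (beyond the scatter). The low number of compound 2 therefore cannot be credited to its hydroxy group alone, and nothing available here explains the size of either step.

It remains open whether the same change from methoxy to hydroxy would have a similar effect with phenoxy on the other ring, since the compounds shown offer that comparison only with dimethylamino. On these data alone, it is also open how an ethoxy group or an amine in place of the methoxy would behave, and so whether the effect is specific to methoxy.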